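Cyclobutyl for methyl on the amide nitrogen of compound 2

The compounds below may be only part of what the source reports. "The series", "measured", "known", "first", "only" and "open" are said of these compounds alone.

Measured so far:
compound 1 `O=C(/C=C1\CCc2ccc(F)cc21)NCCO` gives 42%
compound 2 `CNC(=O)/C=C1\CCc2ccc(F)cc21` gives 45%

Both numbers come from a functional assay on the whole organism with Rattus norvegicus as the target, at a dose of 20 mg/kg by the oral route; a lower number here means less inhibition, a higher number more inhibition at the dose given (going by the name of the read-out). For the measured compounds named here, compound 2 and compound 1 lie within the scatter of each other, the one measured step being a number 3 percentage points higher from compound 1 to compound 2 (within the scatter), so the two cannot be told apart on these numbers.

Compound 3 `O=C(/C=C1\CCc2ccc(F)cc21)NC1CCC1` has not yet been measured. It differs from compound 2 in one place: cyclobutyl in place of methyl on an amide-type nitrogen. Going by the values given here, no measured step changes the amide substituent in this way. Among the compounds with values here, the only step in hand, a number 3 percentage points higher from compound 1 to compound 2 (within the scatter), touches the same amide-type nitrogen and stays within the scatter, which gives no ground for expecting a shift in either direction. The step for compound 3 is therefore expected to be no change at the digits printed from compound 2 to compound 3 (within the scatter), within the scatter. Compound 3 is estimated at 45%, with a range from 25% to 65%.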

Compound 3, a percentage reported as inhibition, in the whole organism at one dose (the size of the read-out at that dose, not a potency): 4%
The estimate for compound 3 lay 41 percentage points above the measured number, outside the stated range (below it).
By their numbers in this assay, from the lowest: compound 3; then compounds 1 and 2 (each within the scatter of the next).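

In this assay, the substituent on the amide nitrogen proves able to change the read-out strongly: cyclobutyl in place of methyl gives a number 41 percentage points lower from compound 2 to compound 3 (beyond the scatter), and cyclobutyl in place of 2-hydroxyethyl gives a number 38 percentage points lower from compound 1 to compound 3 (beyond the scatter). Methyl and 2-hydroxyethyl could not be told apart at this nitrogen, so cyclobutyl is the first group here to stand clear of the others, lying well under both. Nothing available bears on why this substituent behaves so differently.

As far as these compounds go, whether the ring itself or simply a larger carbon group goes with this drop remains open, and an open butyl chain, an isopropyl or a cyclopropyl on the same nitrogen would address that. Also open, from the compounds shown here alone, is how the unsubstituted amide, with two hydrogens on this nitrogen, would compare with methyl and 2-hydroxyethyl.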